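Series notes: thiocarbamate-linked enones, step from compound 3 to 4

The source may hold more compounds than are shown below. What is called first, only, known or untested is meant among the compounds shown, and "the series" means these compounds.

Measured compounds:
compound 1 `COc1cc(/C=C/C(=O)c2ccc(OCCSC(=S)N3CCCC3)cc2)cc(OC)c1OC`: 31700 nM
compound 2 `O=C(/C=C/c1cccs1)c1ccc(OCCSC(=S)N2CCCC2)cc1`: 32400 nM
compound 3 `COc1cc(/C=C/C(=O)c2ccc(OCCSC(=S)N3CCCCC3)cc2)cc(OC)c1OC`: 41300 nM

All three were read in a functional assay on MGC-803 cells (Homo sapiens) for inhibition, read by MTT assay, with a stated time of 72 h; on this read-out higher numbers stand for weaker inhibition and lower numbers for stronger inhibition. Compound 3 holds the highest of the three numbers in this assay, yet neither gap is meaningful: compound 2 and compound 1 both sit within the scatter of it, so no ranking among the three can be stated.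

Compound 4 `COc1cc(/C=C/C(=O)c2ccc(OCCCSC(=S)N3CCCC3)cc2)cc(OC)c1OC` is not yet measured. Relative to compound 3 it carries a group of 9 heavy atoms (6 carbon, 1 nitrogen, 2 sulfur; one five-membered non-aromatic ring with 1 hetero atom) in place of a group of 9 heavy atoms (6 carbon, 1 nitrogen, 2 sulfur; one six-membered non-aromatic ring with 1 hetero atom), on a saturated chain carbon, two bonds along the chain from an oxygen on an aromatic ring; the two have the same atoms, joined differently.

Among the compounds with values here, only one measured step touches this region. From compound 1 to compound 3 the ring on the thiocarbonyl nitrogen was enlarged, giving a 1.3-fold higher number from compound 1 to compound 3 (0.11 log units; within the scatter). Within the data shown here, compound 4 reverses that ring change while also redistributing the chain, and no measured pair covers the chain part. Among the measured compounds shown here, the one relevant step being within the scatter, no shift beyond the scatter is expected in this assay; the expected step from compound 3 to compound 4 is a 1.2-fold lower number from compound 3 to compound 4 (0.07 log units; within the scatter).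

Compound 4 is therefore estimated at 35000 nM, with a range from 15000 nM to 80000 nM.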

Compound 4, half-maximal inhibitory concentration: 14500 nM
Beside the measured number, compound 4's estimate is 2.4-fold (0.38 log units) above it; the measured number lies below the stated range.
By their numbers in this assay, from the lowest: compound 4; then compounds 1, 2 and 3 (each within the scatter of the next).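

Working notes on the chain position: in this assay the longer group in place of the shorter group, both with one five-membered non-aromatic ring with 1 hetero atom, on a saturated chain carbon, gives a 2.2-fold lower number from compound 1 to compound 4 (0.34 log units; beyond the scatter), the first step in the series to lie beyond the scatter and so the first sign that this position responds to a change in chain length. The earlier ring change alone, a 1.3-fold higher number from compound 1 to compound 3 (0.11 log units; within the scatter), stayed within the scatter, whereas the step that joins the reverse ring change to the longer chain, a 2.8-fold lower number from compound 3 to compound 4 (0.45 log units; beyond the scatter), lies beyond it, so among these compounds only the steps that include the longer chain move the number measurably. No measurement at hand says what lies behind this shift.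

Open, on these data alone, is whether a still longer chain lowers the number further or reverses the shift, and whether the same lengthening holds with the piperidin-1-yl group of compound 3 or on the core of compound 2. Also open, as far as these compounds go, is how a morpholine ring on the thiocarbonyl carbon would read at the longer chain length.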